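The source may hold more compounds than are shown below. What is called first, only, known or untested is meant among the compounds shown, and "the series" means these compounds.

Measured compounds:
compound 1, `NC(=O)[C@@H](c1ccccc1)N(C(=O)c1ccccc1)[C@@H]1CCc2c(F)cccc21`, 120 nM
compound 2, `NC(=O)[C@@H](c1ccccc1)N(C(=O)c1ccccc1)[C@@H]1CCc2c(Cl)cccc21`, 720 nM
compound 3, `NC(=O)[C@@H](c1ccccc1)N(C(=O)c1cccnc1)[C@@H]1CCc2c(F)cc(F)cc21`, 110 nM

In an assay on HEK293T cells for antagonist activity at transient receptor potential cation channel subfamily M member 8 (Homo sapiens), read by fluorescence and calcium flux, with a stated time of 60 min (on this read-out higher numbers stand for weaker inhibition and lower numbers for stronger inhibition), compound 1 gives 120 nM, compound 2 gives 720 nM and compound 3 gives 110 nM. Going by the values given here, the one counted step among them, (chloro in place of fluoro on an aromatic carbon), made a 6.0-fold higher number from compound 1 to compound 2 (0.78 log units; beyond the scatter). Compound 3 and compound 1 lie within the scatter of each other; how their two cores differ is not broken down here.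

Compound 4, `NC(=O)[C@@H](c1ccccc1)N(C(=O)c1cccnc1)[C@@H]1CCc2c(F)cc(Cl)cc21`, is not yet measured. It differs from compound 3 by chloro in place of fluoro on an aromatic carbon. Among the compounds with values here, this is the same kind of change as the one from compound 1 to compound 2, but not the same: in compound 2 the chloro sits ortho to a fused ring and meta to a fused ring, whereas in compound 4 it sits meta to a fluoro group, meta to a fused ring and para to a fused ring.

Within the data shown here, because the only measured instance of this kind of change gave a 6.0-fold higher number from compound 1 to compound 2 (0.78 log units; beyond the scatter), the step from compound 3 to compound 4 in this assay is expected to be a 4.5-fold higher number from compound 3 to compound 4 (0.66 log units; beyond the scatter), tempered for the different surroundings. Compound 4 is therefore estimated at 500 nM, expected between 180 nM and 1500 nM.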

Compound 4, half-maximal inhibitory concentration: 110 nM
Compound 4: the middle estimate sits 4.5-fold (0.66 log units) above what was measured; measured number below the stated range.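

In this assay, chloro in place of fluoro on an aromatic carbon gave no change at the digits printed from compound 3 to compound 4 (within the scatter), so on the core of compound 3 this exchange leaves the inhibition where it stood. The same exchange therefore does not have one fixed size in this series, and its size on one core cannot simply be carried to the other: the same change on two cores in this assay, a 6.0-fold higher number (0.78 log units; beyond the scatter) from compound 1 to compound 2 and no change at the digits printed (within the scatter) from compound 3 to compound 4, 6.0-fold (0.78 log units) apart, beyond the scatter of two such steps This does not show which feature is responsible, since the two pairs differ both in their cores and in where the chloro sits, and the compounds shown do not separate these differences; two pairs also set no general rule for other cores.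

The compounds shown leave open whether a bromo, a methyl or a nitrile in place of the chloro of compound 4 would also leave the number unchanged. Going by these compounds alone, they also leave open whether the same exchange at the remaining fluoro group of compound 4 would follow the step seen on compound 1 or the one seen on compound 3.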